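The source may report more compounds than this note shows. Statements on the series, on what has been measured and on what is new or still open speak of the compounds shown alone.

Measured in a functional assay on MCF7 cells (Homo sapiens) for antiproliferative activity, read by MTT assay, with a stated time of 72 h; on this read-out lower numbers stand for stronger inhibition and higher numbers for weaker inhibition:
compound 1 `Cc1cc(NCCN2CCN(C)CC2)nc2ccc(NC(=O)c3ccc(Cl)c(Cl)c3)cc12`: 1700 nM
compound 2 `CCN1CCN(c2cc(C)c3cc(NC(=O)c4ccc5ccccc5n4)ccc3n2)CC1`: 7060 nM

Compound 1 gives the lowest of the two numbers in this assay; the nearest is compound 2, whose value lies higher by a margin beyond the usual scatter. Compounds 1 and 2 differ in more than one place, so their gap is not assigned to a single change.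

Compound 3 `Cc1cc(N2CCN(C(C)C)CC2)nc2ccc(NC(=O)c3ccc(Cl)c(Cl)c3)cc12` is not yet measured. It keeps the amide side of compound 1 and alters the other substituent: 4-isopropylpiperazin-1-yl in place of (2-(4-methylpiperazin-1-yl)ethyl)amino on an aromatic carbon. The donor-bearing linker is gone and the ring sits directly on the aromatic carbon. Going by the values given here, no measured pair isolates this change, so the size of the step is open. The expectation is a step of modest size toward higher numbers in this assay, possibly within the scatter, a 1.8-fold higher number from compound 1 to compound 3 (0.25 log units; within the scatter). Compound 3 is therefore estimated at 3000 nM, with a range from 1000 nM to 9000 nM.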

Compound 3, half-maximal inhibitory concentration: 1710 nM
Beside the measured number, compound 3's estimate is 1.8-fold (0.24 log units) above it; low and high end bracket the measured number.
By their numbers in this assay, from the lowest: compounds 1 and 3 (each within the scatter of the next); then compound 2.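

In this assay, 4-isopropylpiperazin-1-yl in place of (2-(4-methylpiperazin-1-yl)ethyl)amino on this aromatic carbon gives a 1.0-fold higher number from compound 1 to compound 3 (0.00 log units; within the scatter) and so leaves the read-out without a separation between the two groups. With the amide side held constant, losing the hydrogen-bond donor of the leaving group and setting the piperazine ring directly on the aromatic carbon together produce no difference beyond the scatter, though this single pair cannot take those two changes apart. Nothing available explains why the step is so small.

Going by these compounds, whether the same step holds with the amide side of compound 2 stays open. Also open, on these data alone, is how this position responds to a substituent without a piperazine ring, such as a morpholine ring, a simple primary amine or a longer chain ending in a carboxylic acid.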